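The source may hold more compounds than are shown below. What is called first, only, known or untested is meant among the compounds shown, and "the series" means these compounds.

Measured so far:
compound 1 `Cc1n[nH]c(C)c1-c1cncc(-c2ccc(C(N)=O)c(OC(C)C)c2)c1` — 14 nM
compound 2 `O=C(O)c1ccc(-c2cccnc2)s1` — 2900 nM

In an assay on cells for inhibition of MAP kinase-interacting serine/threonine-protein kinase 2 (Homo sapiens), read by mobility shift assay, with stated times of 10 min and 60 min, in the presence of a further agent that is not named here (a lower number here means a stronger inhibitor, a higher number a weaker inhibitor), compound 1 gives 14 nM, the lower of the two numbers; compound 2, at 2900 nM, sits beyond the scatter from it. Compound 3 `Cc1[nH]ncc1-c1cncc(-c2ccc(C(N)=O)c(OC(C)C)c2)c1` has not been measured. It differs from compound 1 by a single change: hydrogen in place of methyl on an aromatic carbon. Going by the values given here, no step between measured compounds shows how much such a change moves the number, so the expectation rests on compound 1 alone. A small weakening step is expected, a 2.5-fold higher number from compound 1 to compound 3 (0.40 log units; beyond the scatter), not far outside the scatter. Compound 3 is therefore estimated to give about 35 nM in this assay, within 12 nM to 120 nM.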

Compound 3, half-maximal inhibitory concentration in the MAP kinase-interacting serine/threonine-protein kinase 2 assay: 16 nM
Estimate against measurement, compound 3: 2.2-fold (0.34 log units) above; low and high end bracket the measured number.
By their numbers in the MAP kinase-interacting serine/threonine-protein kinase 2 assay, from the lowest: compounds 1 and 3 (each within the scatter of the next); then compound 2.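

With hydrogen in place of methyl on this aromatic carbon, the MAP kinase-interacting serine/threonine-protein kinase 2 assay gives a 1.1-fold higher number from compound 1 to compound 3 (0.06 log units; within the scatter), so the number at this position does not depend on that methyl group. In a physicochemical assay for solubility, measured as thermodynamic solubility, at pH 7.4 (a lower number here means a less soluble compound, a higher number a more soluble compound), compound 1 gives 10 ug/mL and compound 3 gives 11 ug/mL, two values within the scatter of each other. Nothing available here offers a reason for either result.

Going by these compounds, whether the remaining methyl group can also be replaced by hydrogen stays open. So does whether an ethyl group, an amine or a fluorine on this carbon would keep these numbers.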